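The source may hold more compounds than are shown below. What is called first, only, known or untested is meant among the compounds shown, and "the series" means these compounds.

Compound 1 `O=C(NC(=S)Nc1nc2ccccc2s1)c1ccc([N+](=O)[O-])cc1`: 62600 nM
Compound 2 `O=C(NC(=S)Nc1nc2cc(Br)ccc2s1)c1ccccc1`: 64600 nM
Compound 3 `Nc1ccc2sc(NC(=S)NC(=O)c3cccs3)nc2c1`: 56100 nM

In a functional assay on HeLa cells (Homo sapiens) for cytotoxicity, read by MTT assay, with a stated time of 24 h (on this read-out higher numbers stand for weaker inhibition and lower numbers for stronger inhibition), compound 3 gives 56100 nM, the lowest of the three numbers, yet its gaps to compound 1 and to compound 2 both fall within the scatter, so the three compounds cannot be told apart on these data. Compound 4 `Nc1ccc2sc(NC(=S)NC(=O)N3CCOCC3)nc2c1` has not yet been measured. It differs from compound 3 in one place: morpholin-4-yl in place of thiophen-2-yl on a carbonyl carbon. Among the measured compounds shown here, no pair of measured compounds differing in one place is available, so the size of this change can only be guessed. The account expects no step beyond the scatter, with compound 4 estimated at 60000 nM (range 25000 nM to 150000 nM), an expected step of a 1.1-fold higher number from compound 3 to compound 4 (0.03 log units; within the scatter).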

Compound 4, half-maximal inhibitory concentration: 45300 nM
The estimate for compound 4 lay 1.3-fold (0.12 log units) above the measured number, within the range that was stated.
By their numbers in this assay, from the lowest: compounds 4, 3, 1 and 2 (each within the scatter of the next).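

The only one-place change among these compounds, on a carbonyl carbon whose other neighbours are an amide-type nitrogen, gives in this assay a 1.2-fold lower number from compound 3 to compound 4 (0.09 log units; within the scatter) and so stays within the scatter. Among the compounds shown here, at this place, morpholin-4-yl, a six-membered non-aromatic ring, can therefore stand in for thiophen-2-yl, a five-membered aromatic ring, with no step that can be told from repeat measurement. No measured evidence bears on this result. From the compounds shown here alone, whether a dimethylamino group or a longer alkyl chain on that same carbonyl carbon would give a step beyond the scatter remains open.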